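The compounds below may be only part of what the source reports. "The series", "measured", "known", "first", "only" and "open" are said of these compounds alone.

In an ADME assay on HEp-2 cells (Homo sapiens) for cytotoxicity (a lower number here means that less compound is tolerated, a higher number that more compound is tolerated), three compounds built on a shared core have been measured. Compound 1 (`CC(C)CCn1c(Cn2c(=O)n(C(C)C)c3ccccc32)nc2c(CN)cccc21`) gives 7000 nM, the lowest of the three numbers. Compound 2 (`CC(C)CCn1c(Cn2c(=O)n(C(C)C)c3ccccc32)nc2cc(CNS(C)(=O)=O)ccc21`) gives 30800 nM, and compound 3 (`CC(C)CCn1c(Cn2c(=O)n(C(C)C)c3ccccc32)nc2ccc(CN(C)C)cc21`) gives 26700 nM. These two values lie within the usual scatter of each other, and both stand above compound 1 by more than that scatter. No two of the three compounds differ in only one place, so the data show no direct measure of any single change.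

Compound 4 (`COCc1cccc2c1nc(Cn1c(=O)n(C(C)C)c3ccccc31)n2CCC(C)C`) is still unmeasured. It departs from compound 1 through methoxy in place of amino on a saturated chain carbon bound to an aromatic carbon, which reads as aminomethyl to methoxymethyl when cut one bond further out: methoxy in place of amino on a saturated chain carbon bound to an aromatic carbon. Compound 4 gives up the aminomethyl group, which neither compound 2 at 30800 nM nor compound 3 at 26700 nM carries. It is therefore expected to move towards those two values, although this comparison is only indirect, since both compounds differ from compound 1 in more than this group. The expected change is a rise beyond the scatter, estimated as a 3.1-fold higher number from compound 1 to compound 4 (0.50 log units; beyond the scatter). For compound 4, the estimate is 22000 nM, with an expected range of 10000 nM to 50000 nM.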

Compound 4, half-maximal cytotoxic concentration: 26700 nM
Compound 4: the middle estimate sits 1.2-fold (0.08 log units) below what was measured, and the stated range covers the measured number.
By their numbers in this assay, from the lowest: compound 1; then compounds 3, 4 and 2 (each within the scatter of the next).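

In this assay, methoxy in place of amino on a saturated chain carbon bound to an aromatic carbon gives a 3.8-fold higher number from compound 1 to compound 4 (0.58 log units; beyond the scatter), a modest step that lies beyond the scatter. Among the compounds shown here, this is the first direct reading of a single change: the earlier compounds differed in more than one place, whereas here aminomethyl to methoxymethyl is the only difference, so the step belongs to this change at this place on the shared core. The data show the size and direction of the step but offer no measurement that accounts for it.

The compounds shown leave open whether the step follows from the departure of the amino group or from the arrival of the methoxy group, a question that a hydroxy group or a plain methyl group at the same place could help to separate. They also leave open whether aminomethyl to methoxymethyl would give a similar step if made elsewhere on the shared core, since this change has been read at only one place.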